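Series notes: triazole benzophenones, whole-animal read-out, step to compound 4

The source may hold more compounds than are shown below. What is called first, only, known or untested is meant among the compounds shown, and "the series" means these compounds.

Measured compounds and values:
compound 1 `CN(C)Cc1nnc(-c2ccco2)n1-c1ccc(Cl)cc1C(=O)c1ccccc1`: 71 mg/kg
compound 2 `Cc1nnc(CN(C)C)n1-c1ccc(Cl)cc1C(=O)c1ccccc1`: 5 mg/kg
compound 3 `CCNCc1nnc(C)n1-c1ccc(Cl)cc1C(=O)c1ccccc1`: 2.5 mg/kg

The read-out is a functional assay on the whole organism (strain CF-1) with Mus musculus as the target; on this read-out lower numbers stand for an effect already at smaller amounts and higher numbers for an effect only at larger amounts of compound. Compound 2 holds the second highest of the three numbers; its nearest neighbour is compound 3, reached by a 2.0-fold lower number from compound 2 to compound 3 (0.30 log units; within the scatter), and its furthest is compound 1, separated by a 14-fold lower number from compound 1 to compound 2 (1.15 log units; beyond the scatter).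

Compound 4 `Cc1nnc(CN(C)C)n1-c1ccc(Cl)cc1C(=O)c1ccccc1Cl` has not been measured. Going by the values given here, it differs from compound 2 by chloro in place of hydrogen on an aromatic carbon; both measured steps, the exchange on the triazole carbon and the exchange on the amine, leave the benzoyl ring untouched, so no measured step bears on this change. There is no basis in the measured compounds for a step in either direction, and the expectation is therefore a number within the scatter of compound 2. For compound 4 the estimate in this assay is 4 mg/kg, expected to fall between 1.5 mg/kg and 12 mg/kg. The expected step is a 1.3-fold lower number from compound 2 to compound 4 (0.10 log units; within the scatter), a size within the usual scatter.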

Compound 4, dose for half-maximal effect: 3.2 mg/kg
Estimate against measurement, compound 4: 1.3-fold (0.10 log units) above, and the stated range covers the measured number.
By their numbers in this assay, from the lowest: compounds 3, 4 and 2 (each within the scatter of the next); then compound 1.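

In this assay, the change from phenyl to 2-chlorophenyl gives a 1.6-fold lower number from compound 2 to compound 4 (0.19 log units; within the scatter), so chloro ortho to a large group on this six-membered aromatic ring of carbon only is accepted, with no effect that can be separated from the scatter. Going by these compounds alone, the earlier steps lay elsewhere in the molecule, so this is the first reading on this ring, and it shows none of the size of the furan-2-yl exchange, a 14-fold lower number from compound 1 to compound 2 (1.15 log units; beyond the scatter). No measured information bears on why this exchange reads as it does.

From the compounds shown here alone, whether fluoro, methoxy or trifluoromethyl in the same place would read like chloro remains open. Also open, going by these compounds, is whether 2-chlorophenyl carries over to the ethylamino side chain of compound 3.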